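This account rests on a few compounds, and the source may have more. Where it says the series, first, only, none or still open, it means among the compounds named here.

In a functional assay on the whole organism (trachea) for inhibition, with Cavia porcellus as the target (a higher number here means that more compound is needed for the effect, a lower number that less compound is needed), the measured compounds are:

- Compound 1 `COc1ccccc1OCC1SCCN1C(=O)COC(C)=O` gives 25 mg/kg
- Compound 2 `COc1ccccc1OCC1SCCN1C(=O)C(C)(C)C` gives 24 mg/kg
- Compound 3 `CCOC(=O)C(C)(C)C(=O)N1CCSC1COc1ccccc1OC` gives 48 mg/kg

Compound 3 stands within the scatter of both other compounds, as shown by a 1.9-fold higher number from compound 1 to compound 3 (0.28 log units; within the scatter) and a 2.0-fold higher number from compound 2 to compound 3 (0.30 log units; within the scatter).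

Compound 4 `COc1ccccc1OCC1SCCN1C(=O)C(C)(C)C(=O)O` carries one change, (hydrogen in place of ethyl on an oxygen next to a carbonyl group). This is hydrogen in place of ethyl on an oxygen next to a carbonyl group, so ethoxycarbonyl becomes carboxy. Within the data shown here, no measured pair makes this change, and no measured compound carries a carboxy group. The closest evidence is the change of the group on the carbonyl carbon, which gave a 1.0-fold lower number from compound 1 to compound 2 (0.02 log units; within the scatter), along with the two steps to compound 3 above. All three lie within the scatter of this assay. A step beyond the scatter is therefore not expected, and no direction can be favoured, although the evidence is indirect and the range must stay wide. The expected change is a 1.0-fold higher number from compound 3 to compound 4 (0.02 log units; within the scatter). For compound 4 the estimate is 50 mg/kg, with an expected range of 17 mg/kg to 150 mg/kg.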

Compound 4, dose for half-maximal effect: 21 mg/kg
Estimate against measurement, compound 4: 2.4-fold (0.38 log units) above, within the range that was stated.
By their numbers in this assay, from the lowest: compounds 4, 2, 1 and 3 (each within the scatter of the next, the first and the last beyond it).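

Among these compounds, changing ethyl to hydrogen on the oxygen next to the carbonyl group, which turns ethoxycarbonyl into carboxy, gives the only step here that passes the scatter: in this assay there is a 2.3-fold lower number from compound 3 to compound 4 (0.36 log units; beyond the scatter), so this position responds to a change confined to the ester oxygen. The carboxy group does not set compound 4 apart from the groups without it, with a 1.1-fold lower number from compound 2 to compound 4 (0.06 log units; within the scatter) and a 1.2-fold lower number from compound 1 to compound 4 (0.08 log units; within the scatter), so a free carboxy group on this chain fits among the tert-butyl and acetoxymethyl compounds. No data shown here account for the step from ethyl to hydrogen.

On these data alone, it remains open whether a methyl ester or a longer chain on that oxygen would read like ethyl or like hydrogen. As far as these compounds go, a primary amide in place of the carboxy group is equally open, as is the same change without the two methyl groups on the chain carbon.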